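The source may report more compounds than this note shows. Statements on the series, on what has been measured and on what is new or still open speak of the compounds shown alone.

The measured compounds and their numbers:

Compound 1, `CC(C)C[C@H](N)CN(C(=O)[C@@H]1C[C@H]1c1ccccc1)c1ccc(-c2ccoc2)cc1`: in a functional assay for agonist activity at G protein-coupled receptor 88 (Homo sapiens), read by HTRF and cAMP accumulation (on this read-out higher numbers stand for an effect only at larger amounts of compound and lower numbers for an effect already at smaller amounts), compound 1 gives 2000 nM.
Compound 2, `COc1ccc(-c2ccc(N(C[C@@H](N)CC(C)C)C(=O)[C@@H]3C[C@H]3c3ccccc3)cc2)cc1`: in this assay compound 2 gives 330 nM.
Compound 3, `CC(C)C[C@H](N)CN(C(=O)[C@@H]1C[C@H]1c1ccccc1)c1ccc(-c2cccc(F)c2)cc1`: in this assay compound 3 gives 2100 nM.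

Compound 3 stands at the highest of the three numbers, though its gap to compound 1 lies within the scatter, so the two cannot be ordered; only compound 2 sits clearly apart, as the step of a 6.4-fold higher number from compound 2 to compound 3 (0.80 log units; beyond the scatter) shows. Compound 4, `CC(C)C[C@H](N)CN(C(=O)[C@@H]1C[C@H]1c1ccccc1)c1ccc(-c2ccc(Cl)cc2)cc1`, differs from compound 3 in one place: 4-chlorophenyl in place of 3-fluorophenyl on an aromatic carbon.

For the measured compounds named here, two measured steps bear on this change. The step of a 1.1-fold higher number from compound 1 to compound 3 (0.02 log units; within the scatter) shows that swapping furan-3-yl for 3-fluorophenyl changed nothing beyond the scatter. The step of a 6.1-fold lower number from compound 1 to compound 2 (0.78 log units; beyond the scatter) shows that 4-methoxyphenyl on the same carbon gave a modest but clear move to lower numbers. Going by the values given here, no measured compound carries 4-chlorophenyl, so the nearest guide is the 4-methoxyphenyl case. Compound 4 is therefore expected to give a lower number than compound 3, with the step of a 2.3-fold lower number from compound 3 to compound 4 (0.37 log units; beyond the scatter) estimated as modest, and its value in this assay expected near 900 nM, within a range from 300 nM to 2500 nM.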

Compound 4, half-maximal effective concentration: 640 nM
The estimate for compound 4 lay 1.4-fold (0.15 log units) above the measured number, and the stated range covers the measured number.
By their numbers in this assay, from the lowest: compounds 2 and 4 (each within the scatter of the next); then compounds 1 and 3 (each within the scatter of the next).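

In this assay, the move to lower numbers at this aromatic carbon turns out not to belong to 4-methoxyphenyl alone: 4-chlorophenyl gives a 3.3-fold lower number from compound 3 to compound 4 (0.52 log units; beyond the scatter) and also a 3.1-fold lower number from compound 1 to compound 4 (0.49 log units; beyond the scatter). Chloro and methoxy cannot be told apart at this position, with a 1.9-fold higher number from compound 2 to compound 4 (0.29 log units; within the scatter). Nothing available explains these steps.

The 3-fluorophenyl and 4-chlorophenyl groups differ in both the halogen and its place on the ring, and the compounds shown leave open which of the two goes with the step; 4-fluorophenyl and 3-chlorophenyl would separate them. Also open, on these data alone, is how an amine or a carboxylic acid on this ring would read in this assay.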